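Swapping an aryl ring for isopropoxy on the shared core

The source may report more compounds than this note shows. Statements on the series, on what has been measured and on what is new or still open speak of the compounds shown alone.

Measured compounds:
compound 1 `Cc1cc(C)c(CN2CCc3ccc(O[C@@H]4CCOC4)c(Cl)c3C2=O)c(=O)[nH]1` 796 nM
compound 2 `Cc1cc(C)c(CN2CCc3ccc(-c4c(C)noc4C)c(Cl)c3C2=O)c(=O)[nH]1` 105 nM

In an assay on cells for inhibition of histone-lysine N-methyltransferase EZH2 (Homo sapiens), read by ELISA, with a stated time of 72 h (a higher number here means a weaker inhibitor, a lower number a stronger inhibitor), compound 2 has the lowest number of the two; compound 1 stands higher by a 7.6-fold lower number from compound 1 to compound 2 (0.88 log units; beyond the scatter), read backwards. Compound 3 `Cc1cc(C)c(CN2CCc3ccc(OC(C)C)c(Cl)c3C2=O)c(=O)[nH]1` carries isopropoxy in place of 3,5-dimethyl-1,2-oxazol-4-yl on an aromatic carbon. For the measured compounds named here, the only measured step that bears on this, a 7.6-fold lower number from compound 1 to compound 2 (0.88 log units; beyond the scatter), went the other way when an alkoxy group gave way to the aryl ring, so the return to an oxygen-linked group in compound 3 is expected to raise the number by about a 5.7-fold higher number from compound 2 to compound 3 (0.76 log units; beyond the scatter). Compound 3 is therefore estimated at 600 nM, within 250 nM to 1500 nM.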

Compound 3, half-maximal inhibitory concentration: 1190 nM
Estimate against measurement, compound 3: 2.0-fold (0.30 log units) below; the range from low to high includes it.
By their numbers in this assay, from the lowest: compound 2; then compounds 1 and 3 (each within the scatter of the next).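

In this assay, isopropoxy in place of 3,5-dimethyl-1,2-oxazol-4-yl gives an 11-fold higher number from compound 2 to compound 3 (1.05 log units; beyond the scatter) and so shows that the lower number of compound 2 holds against a second oxygen-linked group at this aromatic carbon. Isopropyl in place of oxolan-3-yl on the oxygen gives a 1.5-fold higher number from compound 1 to compound 3 (0.17 log units; within the scatter) and thus no change that can be read beyond the scatter. Nothing measured here explains the gap between the five-membered aromatic ring and the oxygen-linked groups. From the compounds shown here alone, whether a phenyl ring, a pyridine ring or an amine at this carbon would match compound 2 stays open.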